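The source may hold more compounds than are shown below. What is called first, only, known or untested is meant among the compounds shown, and "the series" means these compounds.

Measured compounds:
- Compound 1, `OCc1ccc(CNc2cc(Br)cc3[nH]ncc23)cc1`: 45%
- Compound 2, `FC(F)(F)c1cccc(CNc2cc(Br)cc3[nH]ncc23)c1`: 16%

Both compounds were tested in an assay for inhibition of Indoleamine 2,3-dioxygenase 1 (Homo sapiens), with a stated time of 1 h, tested at 10 uM; a lower number here means less inhibition, a higher number more inhibition at the concentration tested (going by the name of the read-out). Going by the values given here, of the two numbers, compound 1 stands highest; the only other reading, from compound 2, is lower by a gap that goes beyond the usual scatter of this kind of measurement, so the two compounds are clearly separated.

Compound 3, `N#Cc1ccc(CNc2cc(Br)cc3[nH]ncc23)cc1`, has not yet been measured. It differs from compound 1 in one place: cyano in place of hydroxymethyl on an aromatic carbon. Among the compounds with values here, no step between two measured compounds matches this change, so there is no direct guide to its size. With only compound 1 and the lower reading of compound 2 to go on, the expected step is a number 15 percentage points lower from compound 1 to compound 3 (beyond the scatter), a fall that may reach beyond the scatter but is not expected to be as deep as the gap to compound 2. For compound 3 the estimated value is 30%, with a range from 10% to 55%.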

Compound 3, a percentage reported as inhibition, at one concentration (the size of the read-out at that concentration, not a potency): 70%
Estimate against measurement, compound 3: 40 percentage points below; the measured number lies above the stated range.
By their numbers in this assay, from the lowest: compound 2; then compound 1; then compound 3.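

In this assay, the group on this aromatic carbon, para to a large group, clearly matters: putting cyano in place of hydroxymethyl gives a number 25 percentage points higher from compound 1 to compound 3 (beyond the scatter). Hydroxymethyl carries a hydrogen-bond donor and cyano carries none, so a donor at this place is not required for the inhibition seen with compound 3. What lies behind the rise cannot be told, as no measured property of these compounds bears on it.

From the compounds shown here alone, it remains open whether a carboxylic acid, an amine or a longer chain at this same place would read above or below compound 3, and so whether cyano is special or just one of many groups that serve here. Going by these compounds, these are also readings at a single concentration, so how far the compounds differ in potency stays open.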